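From fluoro to hydroxy at the assay limit

The source may hold more compounds than are shown below. What is called first, only, known or untested is meant among the compounds shown, and "the series" means these compounds.

- Compound 1 `CCc1ccc(NC(=O)Nc2cc(C)nc3ccccc23)cc1` gives > 25000 nM as a limit
- Compound 2 `Cc1cc(NC(=O)Nc2ccc(F)c(F)c2)c2ccccc2n1` gives > 25000 nM as a limit
- Compound 3 `Cc1cc(NC(=O)Nc2ccc(F)cc2)c2ccccc2n1` gives > 25000 nM as a limit

Compound 3 stands at > 25000 nM in an ADME assay on Raji cells (Homo sapiens) for cytotoxicity, with a stated time of 72 h (a higher number here means that more compound is needed for the effect, a lower number that less compound is needed), and that is a limit, not a number. Within the data shown here, it has no measured neighbour with a true number, and the whole series so far comes down to the limit of > 25000 nM in this assay, at which 3 of the 3 values shown sit, with no exact value among them.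

Compound 4 `Cc1cc(NC(=O)Nc2ccc(O)cc2)c2ccccc2n1` differs from compound 3 in one place: hydroxy in place of fluoro on an aromatic carbon so hydroxy stands in place of fluoro on an aromatic carbon, turning 4-fluorophenyl into 4-hydroxyphenyl.

Among the measured compounds shown here, two measured steps touch this same part of the structure. One is a step that the two limits leave unreadable from compound 1 to compound 3 and the other is a step that the two limits leave unreadable from compound 2 to compound 3 and neither gives a size to carry over. For the measured compounds named here, neither of them involves a hydroxy group, so the new group itself has no measured precedent here. Because the limit of > 25000 nM in this assay, at which 3 of the 3 values shown sit, is all that the series shows, no step beyond the usual scatter is expected in this assay in either direction. The expected result is a number no higher from compound 3 to compound 4 (the limit leaves the size open) and this remains an estimate. A reading at the limit again is the most likely outcome. For compound 4 the estimate is 25000 nM with an expected range from 10000 nM to 40000 nM around it.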

Compound 4, half-maximal effective concentration: > 25000 nM
Compound 4 ended at the assay's limit (the forecaster's own chance of this, stated with the estimate: 75%); the middle value lies on the limit itself.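

In this assay compound 4 gives > 25000 nM, which is a limit and not a number. No step from compound 1 or compound 3 to compound 4 can be read, because the values give no size to compare: the limit of > 25000 nM in this assay, at which 4 of the 4 values shown sit.

The compounds shown leave open whether swapping fluoro, ethyl or hydroxy on this aromatic ring changes the result at all in this assay.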